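Aryl change from compound 3 to compound 4

This account rests on a few compounds, and the source may have more. Where it says the series, first, only, none or still open, it means among the compounds named here.

Values in a functional assay on OVCAR-3 cells (Homo sapiens) for inhibition, read by MTT assay, with a stated time of 24 h; a lower number here means a stronger inhibitor, a higher number a weaker inhibitor:
- compound 1 `CC1(C)[C@H]2CC[C@]1(C)N(Cc1cn(-c3ccccc3Br)nn1)C(=O)C2`: 140 nM
- compound 2 `CC1(C)[C@H]2CC[C@]1(C)N(Cc1cn(-c3ccc(F)cc3)nn1)C(=O)C2`: 200 nM
- compound 3 `COc1ccccc1-n1cc(CN2C(=O)C[C@@H]3CC[C@@]2(C)C3(C)C)nn1`: 140 nM

The three values lie within the scatter of one another, so compound 3 stands apart from neither neighbour. Against compound 1 the reading is no change at the digits printed from compound 1 to compound 3 (within the scatter), and against compound 2 it is a 1.4-fold lower number from compound 2 to compound 3 (0.15 log units; within the scatter).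

The next compound is compound 4 `CC1(C)[C@H]2CC[C@]1(C)N(Cc1cn(-c3ccc(O)cc3)nn1)C(=O)C2`, which carries 4-hydroxyphenyl in place of 2-methoxyphenyl on an aromatic nitrogen.

Every measured step changes this same aryl group on the shared core. The remaining one is a 1.4-fold higher number from compound 1 to compound 2 (0.15 log units; within the scatter). All three steps stay within the scatter in this assay, so the aryl changes tried so far have not moved the number measurably. Among the measured compounds shown here, no measured compound carries 4-hydroxyphenyl, so that group itself is untested, and three compounds are a thin basis. The closest comparison is the 4-fluorophenyl of compound 2 at 200 nM, and the expectation leans slightly towards that value.

No step beyond the scatter is expected, and the estimated change is a 1.3-fold higher number from compound 3 to compound 4 (0.11 log units; within the scatter). For compound 4 the expected value is 180 nM, with an estimated range of 90 nM to 360 nM.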

Compound 4, half-maximal inhibitory concentration: 410 nM
For compound 4 the middle estimate is 2.3-fold (0.36 log units) below the measured one, outside the stated range (above it).
By their numbers in this assay, from the lowest: compounds 1, 3 and 2 (each within the scatter of the next); then compound 4.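

In this assay, among the compounds shown here, the aryl group on the aromatic nitrogen turns out not to be indifferent: 4-hydroxyphenyl gives the first steps that lie beyond the scatter, modest in size, against both 2-substituted aryl groups (a 2.9-fold higher number from compound 3 to compound 4 (0.47 log units; beyond the scatter); a 2.9-fold higher number from compound 1 to compound 4 (0.47 log units; beyond the scatter)). For the compounds shown here, the single swap of hydroxy for fluoro on an aromatic carbon, with the rest of the aryl group unchanged, also lies beyond the scatter (a 2.1-fold higher number from compound 2 to compound 4 (0.31 log units; beyond the scatter)), so the shift does not depend on replacing a 2-substituted aryl group and appears with the hydroxy group in the one pair that differs only in that atom. Nothing at hand explains the shift, and the result stands as an observation on these four compounds only.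

As far as these compounds go, how 4-methoxyphenyl or 4-aminophenyl would read against compound 4 stays open, and that comparison would show whether the step belongs to the hydroxy group in particular. Also open, from the compounds shown here alone, is whether 2-hydroxyphenyl would read with compound 4 or with compound 1 and compound 3, which would show how far the step holds for hydroxy elsewhere on the aryl group.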